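The source may report more compounds than this note shows. Statements on the series, on what has been measured and on what is new or still open speak of the compounds shown alone.

Among the compounds with values here, compound 2 `COc1ccc(Sc2nc3cc(N)cc(N)c3nc2-c2ccccc2)cc1` is the only compound with a number in a functional assay on 786-0 cells (Homo sapiens) for inhibition, read by sulforhodamine B assay, with a stated time of 48 h; a higher number here means that more compound is tolerated, a lower number that less compound is tolerated: in this assay compound 2 gives 70800 nM. Compound 1 `Nc1cc(N)c2nc(-c3ccccc3)c(Oc3ccc(Cl)c(Cl)c3)nc2c1` differs from it in one place, carrying a 3,4-dichlorophenoxy group where compound 2 carries a (4-methoxyphenyl)sulfanyl group. For compound 1 this assay reports only a limit, < 100000 nM. The step that the limit leaves unreadable from compound 1 to compound 2 therefore cannot be read, because the limit of < 100000 nM in this assay, at which 1 of the 2 values shown sits, hides its size. Compound 3 `Nc1cc(N)c2nc(-c3ccccc3)c(Sc3ccc(Cl)c(Cl)c3)nc2c1` keeps the sulfur of compound 2 and takes the ring of compound 1: 3,4-dichlorophenyl in place of 4-methoxyphenyl on a sulfur. Within the data shown here, no measured step bears on this change with a readable size, so nothing here points to a shift in either direction beyond the scatter. The expected step is therefore small, a 1.0-fold lower number from compound 2 to compound 3 (0.00 log units; within the scatter). The estimate for compound 3 in this assay is 70000 nM, within a range from 30000 nM to 160000 nM.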

Compound 3, concentration lethal to 50% of the cells: < 100000 nM
Compound 3 gave a limit, no number (the forecaster's own chance of this, stated with the estimate: 35%); the middle value is on the limit's open side.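

The steps from compound 2 to compound 3 and from compound 1 to compound 3 cannot be read, because compound 1 and compound 3 each give only a limit: the limit of < 100000 nM in this assay, at which 2 of the 3 values shown sit.

In this assay the compounds shown leave open how much swapping the 4-methoxyphenyl for the 3,4-dichlorophenyl group, or the linking oxygen for sulfur, changes the number.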